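Exchanging oxan-4-yl for 1-methylpiperidin-4-yl on compound 3

The source may report more compounds than this note shows. Statements on the series, on what has been measured and on what is new or still open speak of the compounds shown alone.

Compound 1 `Cc1cc2ncccc2cc1Nc1ncc2c(n1)n(C1CCOCC1)c(=O)n2C` gives 2.5
Compound 2 `Cc1cc2nnccc2cc1Nc1ncc2c(n1)n(C1CCOCC1)c(=O)n2C` gives 2.2
Compound 3 `Cc1cc2nccnc2cc1Nc1ncc2c(n1)n(C1CCOCC1)c(=O)n2C` gives 2.2

These three compounds were measured in a physicochemical assay for lipophilicity, read by HPLC, using the shake flask method, measured as octanol-water partition, at pH 7.4 (a higher number here means a more lipophilic compound, a lower number a more polar compound), and all carry oxan-4-yl on an aromatic nitrogen. In this assay compound 3 reads 2.2 and stands level with compound 2 at 2.2 at the digits given. Compound 1 at 2.5 lies within the usual scatter of both, so the three values form one tight group.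

The next structure is compound 4 `Cc1cc2nccnc2cc1Nc1ncc2c(n1)n(C1CCN(C)CC1)c(=O)n2C`, which has 1-methylpiperidin-4-yl in place of oxan-4-yl on an aromatic nitrogen and is otherwise the same as compound 3. Among the compounds with values here, no measured pair shows this exchange, so there is no direct precedent for its size and the margin on any forecast has to be wide. The expectation rests on the structural change itself, with compound 3 at 2.2 as its starting point. A downward move beyond the scatter is expected, and the estimated change is a number 0.60 log units lower from compound 3 to compound 4 (beyond the scatter) in this assay on this reasoning. Compound 4 is therefore estimated to read 1.6 (expected range 1.1 to 2.1) once it is measured.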

Compound 4, distribution coefficient: 1.2
For compound 4 the middle estimate is 0.40 log units above the measured one; the measured number falls inside the stated range.
By their numbers in this assay, from the lowest: compound 4; then compounds 2, 3 and 1 (each within the scatter of the next).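

In this assay, the exchange of oxan-4-yl for 1-methylpiperidin-4-yl on an aromatic nitrogen gives a number 1.00 log units lower from compound 3 to compound 4 (beyond the scatter), so this position can move the reading beyond the scatter, which compounds 1, 2 and 3, all carrying oxan-4-yl, could not show. The step appears although the computed counts barely differ: both groups are six-membered non-aromatic rings with one hetero atom, with no hydrogen-bond donors, one hydrogen-bond acceptor and no net charge, and what changes is an oxygen leaving, a nitrogen entering and one more heavy atom. No measurement available here accounts for the size of this step.

Within the data shown here, the single pair leaves open how much of the step belongs to the ring nitrogen and how much to its methyl group, a question that piperidin-4-yl without the methyl group, or with an acetyl group on the ring nitrogen, would address. It also leaves open whether the same exchange would give a step of similar size on the cores of compound 1 and compound 2.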